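The source may hold more compounds than are shown below. What is called first, only, known or untested is meant among the compounds shown, and "the series" means these compounds.

Series notes. In a functional assay on PC-3 cells (Homo sapiens) for antiproliferative activity, read by MTT assay, with a stated time of 24 h (on this read-out lower numbers stand for stronger inhibition and higher numbers for weaker inhibition), compound 1 `CCn1c(C(=O)NCC(=O)OC)ccc1C(CC)(CC)c1ccc(OCS(=O)(=O)c2ccccc2)c(C)c1` gives > 50000 nM, which is a limit of the assay rather than a number (the limit of > 50000 nM in this assay, at which 1 of the 2 values shown sits). Going by the values given here, compound 2 `CCn1c(C(=O)NCCN)ccc1C(CC)(CC)c1ccc(OCS(=O)(=O)c2ccccc2)c(C)c1` gives 6890 nM in this assay, the only number measured so far. Among the compounds with values here, the single measured step is an at least 7.2-fold lower number from compound 1 to compound 2 (0.86 log units; beyond the scatter) and it is the only reference point available. Compound 3 `CCn1c(C(=O)NCCCO)ccc1C(CC)(CC)c1ccc(OCS(=O)(=O)c2ccccc2)c(C)c1` differs from compound 2 by hydroxymethyl in place of amino on a saturated chain carbon, two bonds along the chain from an amide-type nitrogen. This is not a repeat of the measured step, but the measured step brought the amine in as the number fell, so taking the amine out again in compound 3 is expected to move the number the other way, by a step of roughly a 2.6-fold higher number from compound 2 to compound 3 (0.42 log units; beyond the scatter). Compound 3 is therefore estimated at 18000 nM, within a range of 5000 nM to 60000 nM, with a fair chance that only a limit is reported.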

Compound 3, half-maximal inhibitory concentration: 11300 nM
Estimate against measurement, compound 3: 1.6-fold (0.20 log units) above; measured number inside the range.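

In this assay, the amine is not needed at this position for a measurable number: hydroxymethyl in place of amino gives a 1.6-fold higher number from compound 2 to compound 3 (0.21 log units; within the scatter), so the 2-aminoethyl and 3-hydroxypropyl chains on the amide-type nitrogen cannot be told apart here. The change from methoxycarbonyl to 2-hydroxyethyl gives an at least 4.4-fold lower number from compound 1 to compound 3 (0.64 log units; beyond the scatter), so the drop from compound 1 is not tied to the amine and appears with both compound 2 and compound 3. Compound 1 stands at a limit of the assay and not at a number, so the true size of both steps from it stays unknown: the limit of > 50000 nM in this assay, at which 1 of the 3 values shown sits.

Still open, from the compounds shown here alone, is whether a carboxylic acid, a dimethylamino group or a longer chain at this position would move the number beyond the scatter. Also open, going by these compounds, is how much of the change comes from removing the methoxycarbonyl group itself.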